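Swapping bromo for fluoro on the aryl thiosemicarbazone

The compounds below may be only part of what the source reports. "The series", "measured", "known", "first", "only" and "open" are said of these compounds alone.

Measured compounds:
- compound 1, `S=C(N/N=C/c1ccc2ccccc2n1)Nc1ccc(Br)cc1`: 69400 nM
- compound 2, `Fc1cccc(NC(=S)N/N=C/c2ccc3ccccc3n2)c1`: 79900 nM
- compound 3, `Cc1csc2sc(/C=N/NC(N)=S)c(C)c12`: > 100000 nM

The read-out here is a functional assay on SGC-7901 cells (Homo sapiens) for antiproliferative activity, read by sulforhodamine B assay, with a stated time of 72 h; on this read-out higher numbers stand for weaker inhibition and lower numbers for stronger inhibition. In this assay compound 1 gives 69400 nM, and compound 2, which carries a 3-fluorophenyl in place of the 4-bromophenyl on the amide-type nitrogen, gives 79900 nM; the step of a 1.2-fold higher number from compound 1 to compound 2 (0.06 log units; within the scatter) does not rise above the scatter, so these two sit together with no order between them. For compound 3, built on a different core, the assay reports only a limit, (the limit of > 100000 nM in this assay, at which 1 of the 3 values shown sits), and not a number.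

Compound 4, `Fc1ccc(NC(=S)N/N=C/c2ccc3ccccc3n2)cc1`, differs from compound 1 only at the halogen: fluoro in place of bromo on an aromatic carbon. Going by the values given here, the one measured step that bears on it is the halogen-to-halogen exchange from compound 1 to compound 2, and that step was flat. Among the compounds with values here, there is no measured step that separates a bromo from a fluoro at the same position, so the expectation leans on the flat step alone: little or no change beyond the scatter, with a slight lean toward a higher number given how weak every compound already is.

Compound 4 is therefore expected to give 85000 nM, between 40000 nM and 180000 nM, a step of a 1.2-fold higher number from compound 1 to compound 4 (0.09 log units; within the scatter) that is estimated to stay within the scatter.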

Compound 4, half-maximal inhibitory concentration: 32300 nM
Beside the measured number, compound 4's estimate is 2.6-fold (0.42 log units) above it; measured number outside the range, below it.
By their numbers in this assay, from the lowest: compound 4; then compounds 1 and 2 (each within the scatter of the next). At a limit, above all of these: compound 3.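

In this assay the change from 4-bromophenyl to 4-fluorophenyl gives a 2.1-fold lower number from compound 1 to compound 4 (0.33 log units; beyond the scatter) and so shows that the identity of the halogen matters when its place on the ring stays fixed, something the earlier flat step could not show, since that step changed the halogen and its place together. Going by these compounds alone, with fluoro kept and only the ring position of the group changed, there is a 2.5-fold lower number from compound 2 to compound 4 (0.39 log units; beyond the scatter) and this shows that the place of the fluoro counts as well, so the flat result among the earlier compounds did not mean that this ring was insensitive to change. Both steps are modest, and compound 4 at 32300 nM still needs a high concentration to inhibit these cells, so this is a real but small gain.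

The compounds shown leave open whether a chloro, a methoxy group or an amine on the same aromatic carbon would give a lower or a higher number than fluoro. Nothing given here accounts for why the fluoro compound gives the lower number.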